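Chloro substitution on the dithiazole analog of compound 2

The compounds below may be only part of what the source reports. "The series", "measured", "known", "first", "only" and "open" are said of these compounds alone.

Series notes. Compound 1 `O=c1c(C(=S)Nc2ccccc2)coc2ccccc12` gives 71% in a functional assay on COLO 205 cells (Homo sapiens) for inhibition, read by sulforhodamine B assay, with a stated time of 48 h, tested at 100 uM; a lower number here means less inhibition of growth, a higher number more inhibition of growth at the concentration tested. Compound 2 `O=c1c(C2N=C(c3ccccc3)SS2)coc2ccccc12` gives 18% in this assay. Compound 3 `O=c1c(C(=S)Nc2ccccc2)coc2cc(Cl)c(Cl)cc12` gives 16% in this assay. Among the three numbers compound 2 stands second highest; its nearest neighbour is compound 3, within the scatter, and its furthest is compound 1, beyond the scatter. Compound 4 `O=c1c(C2N=C(c3ccccc3)SS2)coc2ccc(Cl)cc12` is not yet measured; it differs from compound 2 by chloro in place of hydrogen on an aromatic carbon. Going by the values given here, no single-place step between measured compounds covers this change, so its direction is open. Compound 1 and compound 3 differ only in chloro groups on the shared core and give values far apart, but that is not a single-place step. The expected step is a number 2 percentage points higher from compound 2 to compound 4 (within the scatter), none beyond the scatter. Compound 4 is estimated at 20%, range 5% to 40%.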

Compound 4, percent growth inhibition at one concentration: 12%
Estimate against measurement, compound 4: 8 percentage points above; the measured number falls inside the stated range.
By their numbers in this assay, from the lowest: compounds 4, 3 and 2 (each within the scatter of the next); then compound 1.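

In this assay, chloro in place of hydrogen on an aromatic carbon, meta to a fused ring and para to a fused ring, gives a number 6 percentage points lower from compound 2 to compound 4 (within the scatter). Going by these compounds alone, this is the first single-place step, and at this position the change to chloro leaves the number within the scatter. Nothing available bears on why this is so.

Going by these compounds, whether an amine or a methoxy group on the same aromatic carbon would shift the number remains open. Also open, on these data alone, is whether chloro at this position gives a similar step on the core of compound 1.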